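The source may report more compounds than this note shows. Statements on the series, on what has been measured and on what is new or still open speak of the compounds shown alone.

Measured so far:
- compound 1 `CCCC(=O)Nc1ccc(Oc2cccc(OC)c2)cc1`, in an assay on isolated protein for binding affinity to melatonin receptor type 1B (Homo sapiens) (on this read-out higher numbers stand for weaker inhibition and lower numbers for stronger inhibition), compound 1 gives 0.75 nM
- compound 2 `COc1cccc(N(C)c2ccc(NC(C)=O)cc2)c1`, in this assay compound 2 gives 0.23 nM

Compound 2 holds the lower of the two numbers; the gap to compound 1 lies beyond the usual scatter. For the measured compounds named here, no two measured compounds differ in only one place, so no single-step comparison is available.

Compound 3 `COc1cccc(N(C)c2ccc(NC(=O)C3CC3)cc2)c1` differs from compound 2 by cyclopropyl in place of methyl on a carbonyl carbon.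

With no measured step of this kind in the series, the change is expected to stay within the scatter, in either direction, as a 1.3-fold higher number from compound 2 to compound 3 (0.12 log units; within the scatter). Compound 3 is therefore estimated at 0.3 nM, in the range 0.1 nM to 1 nM.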

Compound 3, inhibition constant: 4.8 nM
The estimate for compound 3 lay 16-fold (1.20 log units) below the measured number, outside the stated range (above it).
By their numbers in this assay, from the lowest: compound 2; then compound 1; then compound 3.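

In this assay, for the compounds shown here, cyclopropyl in place of methyl on a carbonyl carbon gives a 21-fold higher number from compound 2 to compound 3 (1.32 log units; beyond the scatter) and so provides the first single-place step. Going by these compounds alone, this position therefore responds strongly to the group on the carbonyl carbon, a sensitivity the earlier compounds could not show. No measurement at hand bears on the reason for this loss.

Open, as far as these compounds go, is whether ethyl on the carbonyl carbon stays closer to methyl or to cyclopropyl. Also open, from the compounds shown here alone, is whether an amine at this place would be accepted.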